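A few compounds are considered here, and "the series" means these few. Any claim that something is new, unique, unknown or untested is made for them only; others in the source may bear on it.

In a functional assay on PC-3 cells (Homo sapiens) for cytotoxicity, read by WST assay, with a stated time of 24 h (a lower number here means a stronger inhibitor, a higher number a weaker inhibitor), compound 3 (`COc1ccc(Cn2cc(/C=C(\C#N)C(=O)c3c[nH]c4cc(F)ccc34)c3ccccc32)cc1`) gives > 50000 nM, which is a limit and not a number. Compound 1 (`N#C/C(=C\c1cn(Cc2ccc(Cl)cc2)c2ccccc12)C(=O)c1c[nH]c2ccccc12`) gives > 50000 nM, also a limit. Compound 2 (`COc1ccc(Cn2cc(/C=C(\C#N)C(=O)c3c[nH]c4cc(OC)ccc34)c3ccccc32)cc1`) gives > 50000 nM, again a limit. Among the measured compounds shown here, the whole series so far stands at the limit of > 50000 nM in this assay, at which 3 of the 3 values shown sit. Compound 4 (`COc1ccc(Cn2cc(/C=C(\C#N)C(=O)c3c[nH]c4ccccc34)c3ccccc32)cc1`) has hydrogen in place of the fluoro of compound 3 on an aromatic carbon, 6-fluoro-1H-indol-3-yl to 1H-indol-3-yl: hydrogen in place of fluoro on an aromatic carbon. For the measured compounds named here, the one measured step that bears on this change, a step that the two limits leave unreadable from compound 2 to compound 3, supplies no size to carry over. In this assay the estimated step that the limit leaves unreadable from compound 3 to compound 4 is therefore nothing beyond the scatter, in no set direction. For compound 4 the estimate is 60000 nM, with an expected range of 30000 nM to 100000 nM.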

Compound 4, half-maximal inhibitory concentration: > 50000 nM
Compound 4 was reported as a limit; the forecaster's own chance of this, stated with the estimate: 85%; the middle value lies beyond the limit too.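

The steps joining compound 4 to compound 1, compound 2 and compound 3 cannot be read in this assay, since all four values are limits: the limit of > 50000 nM in this assay, at which 4 of the 4 values shown sit.

Whether swapping hydrogen, fluoro, methoxy or chloro changes the potency of these compounds stays open.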